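Chloro for bromo on the aryl ketone of compound 3

The source may report more compounds than this note shows. Statements on the series, on what has been measured and on what is new or still open speak of the compounds shown alone.

Compound 3 `CC(=O)c1ccc(Nc2ccnc(SCC(=O)c3ccc(Br)cc3)n2)cc1` gives 17% in a functional assay on SK-MEL-5 cells (Homo sapiens) for inhibition, read by sulforhodamine B assay, with a stated time of 48 h, tested at 10 uM; a lower number here means less inhibition of growth, a higher number more inhibition of growth at the concentration tested. Among the three numbers shown it stands between compound 1 `CC(=O)c1cccc(Nc2ccnc(SCC(=O)c3ccc(C(F)(F)F)cc3)n2)c1`, which gives 14%, and compound 2 `COc1ccc(C(=O)CSc2nccc(Nc3cccc(C(C)=O)c3)n2)cc1`, which gives 22%, and both gaps from compound 3 lie within the scatter. Compound 4 `CC(=O)c1ccc(Nc2ccnc(SCC(=O)c3ccc(Cl)cc3)n2)cc1` differs from compound 3 in one place: chloro in place of bromo on an aromatic carbon. Among the compounds with values here, the only measured step, a number 8 percentage points higher from compound 1 to compound 2 (within the scatter), concerns a different exchange on that ring and lies within the scatter, so no measured step bears directly on a halogen swap. Compound 4 is therefore expected to show a step of no change at the digits printed from compound 3 to compound 4 (within the scatter), none beyond the scatter. For compound 4 an estimated 17% is expected, with a range from 7% to 27% in this assay.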

Compound 4, percent growth inhibition at one concentration: 65%
Estimate against measurement, compound 4: 48 percentage points below, and the stated range ends below it.
By their numbers in this assay, from the lowest: compounds 1, 3 and 2 (each within the scatter of the next); then compound 4.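

In this assay, going from 4-bromophenyl to 4-chlorophenyl gives a number 48 percentage points higher from compound 3 to compound 4 (beyond the scatter), the only step shown that lies beyond the scatter. Within the data shown here, this aromatic carbon, para to a large group, is therefore sensitive to the exchange of one halogen for another, which the earlier compounds, all within the scatter of each other, gave no sign of. Nothing measured here accounts for the step. On these data alone, it remains open whether fluoro or an amine on this carbon would match chloro, and whether chloro would give a similar rise on the core of compound 1 and compound 2.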